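Swapping the Carbamoylphenyl Group of Compound 2 for Oxan-4-yl

The source may hold more compounds than are shown below. What is called first, only, known or untested is meant among the compounds shown, and "the series" means these compounds.

Measured in a physicochemical assay for lipophilicity, at pH 7.4; a higher number here means a more lipophilic compound, a lower number a more polar compound:
- compound 1 `COc1ccc(-c2c(C)nn3c(NCc4ccc(C(N)=O)cc4)nc(C)cc23)cc1OC`: 4.8
- compound 2 `COc1ccc(-c2c(C)nc3c(NCc4ccc(C(N)=O)cc4)nc(C)cn23)cc1OC`: 3.9

Compound 2 holds the lower of these two numbers, and the gap up to compound 1 lies beyond the usual scatter of such measurements. The next compound to be measured, compound 3 `COc1ccc(-c2c(C)nc3c(NCC4CCOCC4)nc(C)cn23)cc1OC`, keeps the core of compound 2 and changes one group: oxan-4-yl in place of 4-carbamoylphenyl on a saturated chain carbon bound to a nitrogen on an aromatic ring. In words, oxan-4-yl stands in place of 4-carbamoylphenyl on a saturated chain carbon bound to a nitrogen on an aromatic ring. Within the data shown here, no measured pair here shows this exchange, so the expectation is a loose one. It starts from compound 2 at 3.9, and in this assay no step beyond the scatter is expected. The expected change is a number 0.10 log units higher from compound 2 to compound 3 (within the scatter). The estimate for compound 3 is 4, with an expected range of 3.5 to 4.5.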

Compound 3, distribution coefficient: 5.2
Compound 3: middle estimate off by 1.20 log units, on the low side; measured number above the stated range.
By their numbers in this assay, from the lowest: compound 2; then compound 1; then compound 3.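

In this assay the exchange moves the number a number 1.30 log units higher from compound 2 to compound 3 (beyond the scatter) and so shows that this position strongly affects the read-out, something compound 1 and compound 2 could not show, as both carry 4-carbamoylbenzyl. The entering group is the smaller by count, with 6 heavy atoms against 9, yet compound 3 has the higher number, so size alone does not set the direction of this step. The exchange also removes the hydrogen-bond donor and the aromatic ring together, and no supporting measurement is available to separate their contributions or explain the step.

As far as these compounds go, a plain benzyl group or a cyclohexylmethyl group at this place would each carry only part of the exchange, so the share of each part remains open. From the compounds shown here alone, whether the step would have the same size on the core of compound 1 is also open.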